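Ethoxy-nitrile series: methoxy for chloro on the pendant phenyl

This account rests on a few compounds, and the source may have more. Where it says the series, first, only, none or still open, it means among the compounds named here.

Three members of the series have numbers in a functional assay on aorta (Rattus norvegicus, strain Wister); a higher number here means a weaker inhibitor, a lower number a stronger inhibitor. Compound 1 `COc1nc(-c2nc3ccccc3n2C)cc(-c2ccc(Cl)cc2)c1C#N` gives 145000 nM. Compound 2 `CCOc1nc(-c2nc3ccccc3n2C)cc(-c2ccc(Cl)cc2)c1C#N` gives 293000 nM, and compound 3 `COc1nc(-c2nc3ccccc3n2C)cc(-c2ccc(C)cc2)c1C#N` gives 295000 nM. Compound 2 thus stands second highest of the three, level with compound 3 within the scatter, while the step of a 2.0-fold higher number from compound 1 to compound 2 (0.31 log units; beyond the scatter) separates it from compound 1.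

Compound 4 `CCOc1nc(-c2nc3ccccc3n2C)cc(-c2ccc(OC)cc2)c1C#N` is not yet measured. It differs from compound 2 by methoxy in place of chloro on an aromatic carbon. The measured step closest to this change is a 2.0-fold higher number from compound 1 to compound 3 (0.31 log units; beyond the scatter), where a different group, methyl, also took the place of chloro on an aromatic carbon and gave a modest weakening. The step from compound 1 to compound 2 does not bear on the new change; it is already built into compound 2. For the measured compounds named here, on that single precedent a modest weakening is expected, with wide uncertainty because only one such step is known. Compound 4 is estimated at 500000 nM (range 200000 nM to 1500000 nM), an expected step of a 1.7-fold higher number from compound 2 to compound 4 (0.23 log units; within the scatter).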

Compound 4, half-maximal inhibitory concentration: 436000 nM
For compound 4 the middle estimate is 1.1-fold (0.06 log units) above the measured one; the range from low to high includes it.
By their numbers in this assay, from the lowest: compound 1; then compounds 2, 3 and 4 (each within the scatter of the next).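

In this assay, for the compounds shown here, the step of a 1.5-fold higher number from compound 2 to compound 4 (0.17 log units; within the scatter) gives the first reading of this exchange on the ethoxy compounds: 4-chlorophenyl to 4-methoxyphenyl, on an aromatic carbon para to a large group. Replacing chloro with methoxy adds a hydrogen-bond acceptor and one more heavy atom, yet the step does not separate the two compounds. The earlier compounds shown here showed only methyl in place of chloro, on a methoxy compound, in the step of a 2.0-fold higher number from compound 1 to compound 3 (0.31 log units; beyond the scatter), which lies beyond the scatter. Nothing in hand explains the outcome of this exchange.

Open, going by these compounds, is whether an amine or a carboxylic acid at this position would give a step beyond the scatter. Also open, on these data alone, is how a longer chain than ethoxy on the oxygen would read alongside the 4-methoxyphenyl group.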